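Ring methyl on the cyclobutane: a second look

A few compounds are considered here, and "the series" means these few. Any claim that something is new, unique, unknown or untested is made for them only; others in the source may bear on it.

Measured compounds in an assay on HEK293 cells for antagonist activity at transient receptor potential cation channel subfamily V member 3 (Homo sapiens), read by FLIPR and calcium flux; a higher number here means a weaker inhibitor, a lower number a stronger inhibitor:
compound 1 `C[C@]1(O)C[C@](c2cccc(C(F)(F)F)c2)([C@H](O)c2ccccn2)C1` gives 1550 nM
compound 2 `O[C@H](c1ccccn1)[C@]1(c2cccc(C(F)(F)F)c2)C[C@H](O)C1` gives 90 nM
compound 3 `O[C@H](c1ccccn1)[C@]1(c2ccnc(C(F)(F)F)c2)C[C@@H](O)C1` gives 530 nM

Compounds 2 and 1 share a core and differ in one place, (methyl in place of hydrogen on a saturated ring carbon). That change gives a 17-fold higher number from compound 2 to compound 1 (1.24 log units; beyond the scatter), so the added methyl on the ring carbon bearing the hydroxy group is the single clearest effect in this small set.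

Compound 3 carries a different aryl group from compound 2; the difference between the two cores is not broken down here. Compound 3 sits between the other two in this assay, with a weaker number than compound 2 and a stronger number than compound 1.

Compound 4 `C[C@]1(O)C[C@@](c2ccnc(C(F)(F)F)c2)([C@H](O)c2ccccn2)C1` is not yet measured. It differs from compound 3 by methyl in place of hydrogen on a saturated ring carbon. For the measured compounds named here, the place description matches the one for the change from compound 2 to compound 1 word for word, so this is the same change applied to the other core. Because the step of a 17-fold higher number from compound 2 to compound 1 (1.24 log units; beyond the scatter) is large and well beyond the scatter, the expectation for compound 4 is a step of similar size in the same direction, a 13-fold higher number from compound 3 to compound 4 (1.12 log units; beyond the scatter), though a single precedent gives no guarantee that the two cores respond alike. On that basis compound 4 is estimated at 7000 nM in this assay, with a plausible range from 2500 nM to 20000 nM; a value this weak may be reported only as a limit.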

Compound 4, antagonist equilibrium constant: 4270 nM
For compound 4 the middle estimate is 1.6-fold (0.21 log units) above the measured one; low and high end bracket the measured number.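

In this assay, methyl in place of hydrogen on a saturated ring carbon of the four-membered ring again gives a weaker inhibitor on the second core, with an 8.1-fold higher number from compound 3 to compound 4 (0.91 log units; beyond the scatter). The change therefore carries over between these two cores in direction, and the two step sizes cannot be told apart on these data: the same change on two cores in this assay, a 17-fold higher number (1.24 log units; beyond the scatter) from compound 2 to compound 1 and an 8.1-fold higher number (0.91 log units; beyond the scatter) from compound 3 to compound 4, 2.1-fold (0.33 log units) apart, within the scatter of two such steps. This rests on a single pair per core at a single ring position, so it supports transfer between these two cores in this one read-out, but it does not show that the step would hold on a further core, and it gives no reason why the methyl costs potency.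

As far as these compounds go, it remains open what a longer chain such as ethyl on the same ring carbon would do to the number, and whether an amine in place of the hydroxy group on that carbon would follow the same trend. From the compounds shown here alone, it is also open whether the methyl step seen in this assay would appear at all with a carboxylic acid or a nitrile on the ring carbon instead of the hydroxy group.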